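From Chloro to Methylsulfanyl on the Shared Core

The compounds below may be only part of what the source reports. "The series", "measured", "known", "first", "only" and "open" are said of these compounds alone.

Measured so far in a functional assay on the whole organism with Rattus norvegicus as the target; on this read-out higher numbers stand for an effect only at larger amounts of compound and lower numbers for an effect already at smaller amounts (both values are limits):
Compound 1 (`COc1nc(C)cc(SC)c1NC(=O)N(Cc1ccc(Oc2ccc(F)cc2)cc1)C1CCCCCC1`) gives < 0.032 mg/kg (a limit)
Compound 2 (`Cc1cc(Cl)c(NC(=O)N(Cc2ccc(Oc3ccc(F)cc3)cc2)C2CCCCCC2)c(Cl)n1`) gives > 0.1 mg/kg (a limit)

Compound 2 stands at the higher end of the two values shown, and its > 0.1 mg/kg is a limit, not a number. Compound 3 (`CSc1nc(C)cc(Cl)c1NC(=O)N(Cc1ccc(Oc2ccc(F)cc2)cc1)C1CCCCCC1`) differs from it in one place: methylsulfanyl in place of chloro on an aromatic carbon, with methylsulfanyl in place of chloro on an aromatic carbon, next to the ring nitrogen. Among the compounds with values here, one measured step bears on this, and only in part. The step of an at least 3.1-fold higher number from compound 1 to compound 2 (0.49 log units; beyond the scatter) lost a methylsulfanyl group along with other changes, and it lies beyond the scatter. A move toward lower numbers is therefore expected, its size left open by the limit on compound 2. An estimated at least 1.6-fold lower number from compound 2 to compound 3 (0.22 log units; that floor lies within the scatter) is expected on that basis. Compound 3 is estimated at 0.06 mg/kg with 0.02 mg/kg to 0.2 mg/kg as its expected range.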

Compound 3, dose for half-maximal effect: < 0.1 mg/kg
Compound 3: no number, only a limit (the forecaster's own chance of this, stated with the estimate: 40%); the middle value is on the limit's open side.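

In this assay compound 3 gives < 0.1 mg/kg as a limit and not a number. Methylsulfanyl in place of chloro next to the ring nitrogen, here the only change on the shared core, gives a number no higher from compound 2 to compound 3 (the limit leaves the size open) and so isolates this swap, which the earlier step had mixed with other changes. Nothing shown gives a reason for this result.

Neither the size of that step nor the step between compound 1 and compound 3 can be read, as the values involved are limits. On these data alone, how an amine or a longer chain such as ethylsulfanyl would fare at this position also stays open.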